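A few compounds are considered here, and "the series" means these few. Any claim that something is new, unique, unknown or untested is made for them only; others in the source may bear on it.

Compound 3 `O=C(NO)c1cccc(OCc2ccc(-c3noc(-c4ccc(Br)cc4)n3)cc2)c1` gives > 100000 nM in an assay on isolated protein for inhibition of sphingomyelin phosphodiesterase (Homo sapiens), read by fluorescence, with a stated time of 30 min (a higher number here means a weaker inhibitor, a lower number a stronger inhibitor), and this is a limit of the assay rather than a number (the limit of > 100000 nM in this assay, at which 1 of the 3 values shown sits). For comparison, compound 1 `CCCCCCc1ccc(COc2cccc(C(=O)NO)c2)cc1` gives 2110 nM in this assay, and compound 2 `O=C(NO)c1cccc(OCc2ccc(-c3cccnc3)cc2)c1` gives 52300 nM. Within the data shown here, the single measured step, a 25-fold higher number from compound 1 to compound 2 (1.39 log units; beyond the scatter), changes a different place on the shared core, so it says little about the change to compound 4 `O=C(NO)c1cccc(OCc2ccc(-c3noc(CCc4ccccc4)n3)cc2)c1`, in which (phenethyl in place of 4-bromophenyl on an aromatic carbon). Because compound 3 stands at > 100000 nM, a move in either direction would be hard to see. The value for compound 4 is therefore expected to stay near that limit, estimated at 150000 nM with a range from 30000 nM to 600000 nM. The step that the limit leaves unreadable from compound 3 to compound 4 is thus expected to be none beyond the scatter.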

Compound 4, half-maximal inhibitory concentration: 1730 nM
For compound 4 the middle estimate is 87-fold (1.94 log units) above the measured one, and the stated range ends above it.
By their numbers in this assay, from the lowest: compounds 4 and 1 (each within the scatter of the next); then compound 2. At a limit, above all of these: compound 3.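

In this assay compound 3 stands at a limit of the assay, not a number: the limit of > 100000 nM in this assay, at which 1 of the 4 values shown sits. Phenethyl in place of 4-bromophenyl at this carbon of the five-membered ring gives an at least 57-fold lower number from compound 3 to compound 4 (1.76 log units; beyond the scatter), so this position, unseen in the earlier step, can strongly change the reading. The swap takes a compound from the limit to a measurable value.

The compounds shown cannot separate the loss of bromine from the added chain. An unsubstituted phenyl, a benzyl or a 4-bromophenethyl group at this position would help tell these apart.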